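The source may hold more compounds than are shown below. What is called first, only, known or untested is meant among the compounds shown, and "the series" means these compounds.

Compound 1 `CN(C)/C(=N/CCCCn1nc(-c2ccccc2)ccc1=O)NC#N`: 52.9 mg/kg
Compound 2 `CC/N=C(/NC#N)NCCCCn1nc(-c2ccccc2)ccc1=O`: 60.7 mg/kg
Compound 3 `CC/N=C(/NC#N)NCCCCCCn1nc(-c2ccccc2)ccc1=O`: > 100 mg/kg

All three values come from a functional assay on the whole organism with Rattus norvegicus as the target; a lower number here means that less compound is needed, a higher number that more compound is needed for the effect. Among the two numbers available, compound 2 holds the highest, and compound 1 sits within the scatter of it. For compound 3 this assay reports only a limit, namely (the limit of > 100 mg/kg in this assay, at which 1 of the 3 values shown sits), not a number.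

Compound 4 `C=CCNC(=S)NCCCCn1nc(-c2ccccc2)ccc1=O` is not yet measured. It differs from compound 2 by a group of 6 heavy atoms (4 carbon, 1 nitrogen, 1 sulfur; no ring) in place of a group of 7 heavy atoms (4 carbon, 3 nitrogen; no ring), on an amine nitrogen. Among the measured compounds shown here, only one measured step touches the same end of the molecule: a 1.1-fold higher number from compound 1 to compound 2 (0.06 log units; within the scatter), a swap of one chain group for another of equal size that left the result within the scatter. That is thin evidence, and the present change also removes the nitrile and brings in sulfur, so it cannot be read as a simple repeat. With nothing pointing either way, no step beyond the scatter is expected in this assay.

Compound 4 is therefore estimated to give about 60 mg/kg, with a range from 25 mg/kg to 150 mg/kg. The expected step from compound 2 is a 1.0-fold lower number from compound 2 to compound 4 (0.01 log units; within the scatter), which would stay within the scatter.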

Compound 4, dose for half-maximal effect: 78.6 mg/kg
Compound 4: middle estimate off by 1.3-fold (0.12 log units), on the low side, and the stated range covers the measured number.
By their numbers in this assay, from the lowest: compounds 1, 2 and 4 (each within the scatter of the next). At a limit, above all of these: compound 3.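

The earlier step swapped one nitrile-bearing group for another, whereas here the nitrile leaves and sulfur enters, and in this assay the result still lies within the scatter (a 1.3-fold higher number from compound 2 to compound 4 (0.11 log units; within the scatter)). The comparison with the other measured neighbour, a somewhat larger swap at the same end of the molecule, also lies within the scatter (a 1.5-fold higher number from compound 1 to compound 4 (0.17 log units; within the scatter)), showing that among these compounds this end accepts a sulfur-bearing group without a readable change. Nothing measured here explains this tolerance.

Going by these compounds, compound 3, with its longer chain, has only a limit, > 100 mg/kg, and it remains open whether the sulfur-bearing group would behave the same way on that chain. Also open, on these data alone, is how a urea, with oxygen in place of the sulfur, or an end group carrying a phenyl ring would read in this assay.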